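Thiazole carboxamides on an indole core: trimethoxy variant of compound 2

The source may hold more compounds than are shown below. What is called first, only, known or untested is meant among the compounds shown, and "the series" means these compounds.

Measured so far:
- compound 1, `COc1cc(NC(=O)c2csc(-c3c[nH]c4ccc(Br)cc34)n2)cc(OC)c1OC`: > 100000 nM
- compound 2, `O=C(Nc1ccccc1)c1csc(-c2cn(Cc3ccc(Cl)cc3)c3ccccc23)n1`: 76400 nM

Going by the values given here, in a functional assay on PC-3 cells (Homo sapiens) for cytotoxicity, read by MTT assay, with a stated time of 48 h, in the absence of a further agent (on this read-out higher numbers stand for weaker inhibition and lower numbers for stronger inhibition), compound 2 gives 76400 nM, the only number in the set. Compound 1 reaches only the assay limit, > 100000 nM, and stands there as the limit of > 100000 nM in this assay, at which 1 of the 2 values shown sits. Compound 2 is therefore the one measured point, and it sits at weak inhibition.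

Compound 3, `COc1cc(NC(=O)c2csc(-c3cn(Cc4ccc(Cl)cc4)c4ccccc34)n2)cc(OC)c1OC`, differs from compound 2 by 3,4,5-trimethoxyphenyl in place of phenyl on an amide-type nitrogen. The same 3,4,5-trimethoxyphenyl on the amide nitrogen is carried by compound 1, but compound 1 also differs in its indole part, so the two values show no isolated comparison.

Expectation: the step of a 1.2-fold higher number from compound 2 to compound 3 (0.09 log units; within the scatter) is estimated as small, at or a little beyond the scatter, toward weaker inhibition. For compound 3 the expected value in this assay is 95000 nM, within 30000 nM to 300000 nM, with a fair chance that only a limit is reported.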

Compound 3, half-maximal inhibitory concentration: > 100000 nM
Compound 3: only a limit was reported; the forecaster's own chance of this, stated with the estimate: 45%; middle value at least 1.0-fold (0.02 log units) away from the limit.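

Going by these compounds alone, replacing phenyl with 3,4,5-trimethoxyphenyl on the amide-type nitrogen gives the one isolated comparison at this position in this assay: an at least 1.3-fold higher number from compound 2 to compound 3 (0.11 log units; that floor lies within the scatter). Compound 3 gives > 100000 nM, which is a limit of the assay and not a number. The change therefore shows no gain toward stronger inhibition at this position, and the set now stands largely at one limit: the limit of > 100000 nM in this assay, at which 2 of the 3 values shown sit.

On these data alone, the size of the step beyond its floor remains unknown, as does whether any change at this position can move the value toward stronger inhibition. As far as these compounds go, it also remains open whether an aminophenyl or carboxyphenyl group, or a single methoxy group on the phenyl, would give a number within the range of this assay.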